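The source may hold more compounds than are shown below. What is called first, only, known or untested is meant among the compounds shown, and "the series" means these compounds.

In a physicochemical assay for lipophilicity, read by HPLC (a lower number here means a more polar compound, a higher number a more lipophilic compound), compound 1 `COC(=O)C1(c2ccc(NC(=O)Nc3cccnc3Oc3ccccc3C(C)(C)C)cc2)CC1` gives 5.1 and compound 2 `CC(C)(C)c1ccccc1Oc1ncccc1NC(=O)Nc1ccc(-c2ccccc2CO)cc1F` gives 5.5 as the higher of the two, a gap beyond the scatter. Compound 3 `CN(C)Cc1ccc(NC(=O)Nc2cccnc2Oc2ccccc2C(C)(C)C)c(F)c1` differs from compound 2 by the change (dimethylamino)methyl in place of 2-(hydroxymethyl)phenyl on an aromatic carbon in one place: (dimethylamino)methyl in place of 2-(hydroxymethyl)phenyl on an aromatic carbon. Among the measured compounds shown here, no measured pair shows this change, so the expectation rests on the structural change alone. In this assay a fall beyond the scatter is expected, estimated as a number 1.10 log units lower from compound 2 to compound 3 (beyond the scatter) in size. The estimated value for compound 3 is 4.4 with an expected range from 3.7 to 5.1 once measured.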

Compound 3, partition coefficient: 4.2
The estimate for compound 3 lay 0.20 log units above the measured number, within the range that was stated.
By their numbers in this assay, from the lowest: compound 3; then compound 1; then compound 2.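

In this assay, among the compounds shown here, the change to (dimethylamino)methyl in place of 2-(hydroxymethyl)phenyl, para to a large group and meta to a fluoro group, gives a number 1.30 log units lower from compound 2 to compound 3 (beyond the scatter) as the first one-place step. The number therefore depends strongly on the group at this position, although this single step cannot separate loss of the aromatic ring from entry of the nitrogen. No available measurement explains the size of this step. Still open, from the compounds shown here alone, is where a carboxylic acid or a morpholinylmethyl group at this position would fall in this assay.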